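Two Aryl Swaps on a Shared Sugar-Linked Malonate Core

A few compounds are considered here, and "the series" means these few. Any claim that something is new, unique, unknown or untested is made for them only; others in the source may bear on it.

Compound 1 `CCOC(=O)C(C(=O)OCC)C(CC(=O)C[C@@H]1O[C@H](CO)[C@@H](O)[C@H](O)[C@H]1O)c1ccc(Cl)cc1` gives -6% in an assay for inhibition of glucose-6-phosphatase catalytic subunit 1 (Rattus norvegicus), tested at 100 uM (on this read-out higher numbers stand for more inhibition at the one concentration tested (going by the name of the read-out) and lower numbers for less inhibition), and compound 2 `CCOC(=O)C(C(=O)OCC)C(CC(=O)C[C@@H]1O[C@H](CO)[C@@H](O)[C@H](O)[C@H]1O)c1ccc2ccccc2c1` gives 4.6%. For the measured compounds named here, the only step measured so far, a number 10.6 percentage points higher from compound 1 to compound 2 (beyond the scatter), is modest but beyond the scatter. On these two numbers compound 2 stands highest, with compound 1 as its nearest neighbour a number lower by that same step.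

Compound 3 `CCOC(=O)C(C(=O)OCC)C(CC(=O)C[C@@H]1O[C@H](CO)[C@@H](O)[C@H](O)[C@H]1O)c1cccnc1` differs from compound 2 in one place: pyridin-3-yl in place of naphthalen-2-yl on a saturated chain carbon bound to two saturated chain carbons. Going by the values given here, the single measured step bears on this change only loosely: in that step a larger aromatic group, naphthalen-2-yl, replaced a smaller one, 4-chlorophenyl, and the number rose modestly. Here the larger group leaves again and a smaller, nitrogen-containing ring enters, so the number is expected to fall back towards that of compound 1, with the step of a number 5.6 percentage points lower from compound 2 to compound 3 (within the scatter) expected for compound 3 to be small and likely within the scatter. Compound 3 is therefore estimated to give -1%, within a range from -14% to 10%.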

Compound 3, a percentage reported as inhibition, at one concentration (the size of the read-out at that concentration, not a potency): 37.6%
For compound 3 the middle estimate is 38.6 percentage points below the measured one; measured number above the stated range.
By their numbers in this assay, from the lowest: compound 1; then compound 2; then compound 3.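

For the compounds shown here, at this position, on a saturated chain carbon bound to two saturated chain carbons, the choice of aromatic group can move the number in this assay much further than the earlier pair showed: the change from naphthalen-2-yl to pyridin-3-yl gives a number 33 percentage points higher from compound 2 to compound 3 (beyond the scatter), and the change from 4-chlorophenyl to pyridin-3-yl gives a number 43.6 percentage points higher from compound 1 to compound 3 (beyond the scatter), both large where the only earlier step, a number 10.6 percentage points higher from compound 1 to compound 2 (beyond the scatter), was modest. That earlier step could be read as a gain from a larger aromatic group, but compound 3, with one six-membered aromatic ring holding 1 hetero atom, goes against that reading and gives the highest number of the three. Nothing available here says why the number moved so far.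

The compounds shown leave open whether the ring nitrogen of pyridin-3-yl carries this change, or whether a plain phenyl group would do the same, and whether a pyridin-4-yl group at this place would match it. Also open, on these data alone, is whether a carboxylic acid in place of the ethyl esters would change the number in this assay.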